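Methyl for Methoxy on the Aryl Arm of a Hydroxamic Acid

A few compounds are considered here, and "the series" means these few. Any claim that something is new, unique, unknown or untested is made for them only; others in the source may bear on it.

Measured so far:
compound 1 `Cc1cccc(-c2nc(CNc3ccc(C(=O)NO)cc3)n(-c3ccccc3)n2)c1`: 281 nM
compound 2 `COc1ccc(-c2nc(CNc3ccc(C(=O)NO)cc3)n(-c3ccccc3)n2)cc1`: 163 nM
compound 3 `O=C(NO)c1ccc(NCc2nc(-c3ccccc3)nn2-c2cccc(Cl)c2)cc1`: 678 nM

All three share one core and were tested in an assay on Sf9 cells for inhibition of protein deacetylase HDAC6 (Homo sapiens), read by fluorescence, with a stated time of 40 min; a lower number here means a stronger inhibitor, a higher number a weaker inhibitor. Compound 2 and compound 1 lie within the scatter of each other, while compound 3 sits beyond the scatter above both. Compound 4 `Cc1ccc(-c2nc(CNc3ccc(C(=O)NO)cc3)n(-c3ccccc3)n2)cc1` differs from compound 2 in one place: methyl in place of methoxy on an aromatic carbon. Going by the values given here, only one measured step bears on this: a 1.7-fold lower number from compound 1 to compound 2 (0.24 log units; within the scatter), which exchanged 3-methylphenyl for 4-methoxyphenyl and stayed within the scatter. Among the compounds with values here, no measured pair sets methyl against methoxy on the same carbon, so guidance is thin. A step within the scatter, a 1.3-fold higher number from compound 2 to compound 4 (0.13 log units; within the scatter), is therefore expected for compound 4. Compound 4 is estimated at 220 nM, with a range from 110 nM to 450 nM.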

Compound 4, half-maximal inhibitory concentration: 224 nM
Estimate against measurement, compound 4: 1.0-fold (0.01 log units) below; the measured number falls inside the stated range.
By their numbers in this assay, from the lowest: compounds 2, 4 and 1 (each within the scatter of the next); then compound 3.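

In this assay, methyl in place of methoxy gives a 1.4-fold higher number from compound 2 to compound 4 (0.14 log units; within the scatter) and so, at this para carbon, removing the oxygen of the methoxy group leaves the result within the scatter. The methyl group's place can now be read alone, as 4-methylphenyl in place of 3-methylphenyl gives a 1.3-fold lower number from compound 1 to compound 4 (0.10 log units; within the scatter) and also stays within the scatter, whereas the earlier step changed both group and place at once. No evidence at hand explains these small steps.

Going by these compounds, whether an amine or a carboxylic acid on this carbon would move the number beyond the scatter remains open.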